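Chloro for Methyl on the Pendant Phenyl of Compound 3

A few compounds are considered here, and "the series" means these few. Any claim that something is new, unique, unknown or untested is made for them only; others in the source may bear on it.

In a functional assay on the whole organism (plasma, strain Wistar) with Rattus norvegicus as the target, with a stated time of 15 days, at a dose of 3 mg/kg by the oral route (a higher number here means a stronger effect of the compound at the dose given, a lower number a weaker effect), compound 1 `Cc1nc(COc2ccc(/C=C3\SC(=O)NC3=O)cc2)cs1` gives 10.4%, compound 2 `O=C1NC(=O)/C(=C/c2ccc(OCc3csc(-c4ccccc4)n3)cc2)S1` gives 17.8%, and compound 3 `Cc1ccc(-c2nnc(SCCOc3ccc(/C=C4\SC(=O)NC4=O)cc3)[nH]2)cc1` gives 16.9%. Compound 3 stands second highest of the three numbers, with compound 2 and compound 1 both within the scatter of it. Compound 4 `O=C1NC(=O)/C(=C/c2ccc(OCCSc3nnc(-c4ccc(Cl)cc4)[nH]3)cc2)S1` differs from compound 3 by chloro in place of methyl on an aromatic carbon. Among the measured compounds shown here, no measured step exchanges a group on this phenyl; the only measured step, a number 7.4 percentage points higher from compound 1 to compound 2 (within the scatter), exchanges a group at another place and stays within the scatter. The data therefore give no ground to expect a step beyond the scatter in this assay. Compound 4 is expected to show a step of a number 0.1 percentage points higher from compound 3 to compound 4 (within the scatter), giving an estimated 17% with a range from 8% to 26%.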

Compound 4, a percentage reported as activity, at one dose (the size of the read-out at that dose, not a potency): 16%
Compound 4: middle estimate off by 1 percentage points, on the high side; the measured number falls inside the stated range.
By their numbers in this assay, from the lowest: compounds 1, 4, 3 and 2 (each within the scatter of the next).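

In this assay, among the compounds shown here, the change from 4-methylphenyl to 4-chlorophenyl gives a number 0.9 percentage points lower from compound 3 to compound 4 (within the scatter), the only measured step on this phenyl. At this place, para to a large group, chloro in place of methyl therefore leaves the read-out within the scatter at the dose given. No measurement shown bears on the reason for this result. On these data alone, whether an amine or a carboxylic acid on this phenyl would give a step beyond the scatter remains open. So does whether chloro and methyl would also read alike at another dose.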